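Halogen Swap on the Aryl Amide of Compound 1

The source may hold more compounds than are shown below. What is called first, only, known or untested is meant among the compounds shown, and "the series" means these compounds.

Measured compounds:
- compound 1 `Cn1c(Cc2nn(C)c(=O)c3ccccc23)nnc1SCC(=O)Nc1ccc(I)cc1`: "not active" (no number reported)
- compound 2 `Cn1c(Cc2nn(C)c(=O)c3ccccc23)nnc1SCCCCCCCC(=O)Oc1ccc(Cl)cc1Cl`: 800 nM
- compound 3 `CC(C)Oc1ccc(NC(=O)CCCCCCCSc2nnc(Cc3nn(C)c(=O)c4ccccc34)n2C)cc1`: 1100 nM

In an assay on isolated protein (Mus musculus) for inhibition of IL15-IL15 receptor (Homo sapiens), read by resazurin assay, with stated times of 30 min and 2.5 days (a lower number here means a stronger inhibitor, a higher number a weaker inhibitor), compound 1 gives "not active" (no number reported), so no single number places it on the scale. Compound 2 gives 800 nM in this assay, and compound 3 gives 1100 nM; the step of a 1.4-fold higher number from compound 2 to compound 3 (0.14 log units; within the scatter) shows that exchanging the terminal group at the end of the long chain leaves the result essentially unchanged.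

Compound 4 `Cn1c(Cc2nn(C)c(=O)c3ccccc23)nnc1SCC(=O)Nc1ccc(F)cc1F` differs from compound 1 only at the ring on the amide-type nitrogen: 2,4-difluorophenyl in place of 4-iodophenyl on an amide-type nitrogen. Within the data shown here, no measured step bears on this change; the one step known, a 1.4-fold higher number from compound 2 to compound 3 (0.14 log units; within the scatter), concerns the long-chain series and not the short linker shared by compound 1 and compound 4. Since compound 1 was reported as inactive, and the shared core and short linker are kept, compound 4 is expected to be weak as well, with a fair chance that this assay again reports no number. The estimate for compound 4 is 15000 nM, within a range of 3000 nM to 80000 nM.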

Compound 4, half-maximal inhibitory concentration: "not active" (no number reported)
Compound 4: no number reported; there is nothing to compare the estimate with.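

Compound 1 and compound 4 both come without a number, so no step can be read between them. Nothing given here accounts for this result. The compounds shown leave open whether any other ring on the amide-type nitrogen would bring a number in this assay.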